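A few compounds are considered here, and "the series" means these few. Any claim that something is new, unique, unknown or untested is made for them only; others in the source may bear on it.

Measured in a functional assay on SiHa cells (Homo sapiens) for inhibition, read by CCK-8 assay, with a stated time of 72 h, tested at 1 uM; a lower number here means less inhibition of growth, a higher number more inhibition of growth at the concentration tested:
- compound 1 `CN(C)C(=O)c1cc2cnc(Nc3ccc(NC(=O)C4(C(=O)Nc5ccc(Cl)cc5)CC4)cc3)nc2n1C1CCCC1`: -0.8%
- compound 2 `CN(C)C(=O)c1cc2cnc(Nc3ccc(NC(=O)C4(C(=O)Nc5cccc(F)c5)CC4)cc3)nc2n1C1CCCC1`: 29.7%
- compound 3 `CN(C)C(=O)c1cc2cnc(Nc3ccc(NC(=O)C4(C(=O)Nc5cccc(Cl)c5)CC4)cc3)nc2n1C1CCCC1`: 16.2%

Compound 3 is the second highest of these three numbers, with a number 17 percentage points higher from compound 1 to compound 3 (beyond the scatter) and a number 13.5 percentage points lower from compound 2 to compound 3 (beyond the scatter).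

The next compound is compound 4 `CN(C)C(=O)c1cc2cnc(Nc3ccc(NC(=O)C4(C(=O)Nc5ccc(Cl)c(C(F)(F)F)c5)CC4)cc3)nc2n1C1CCCC1`, which differs from compound 3 as follows: 4-chloro-3-(trifluoromethyl)phenyl in place of 3-chlorophenyl on an amide-type nitrogen. In words, 4-chloro-3-(trifluoromethyl)phenyl stands in place of 3-chlorophenyl on an amide-type nitrogen.

Among the measured compounds shown here, no measured step adds a trifluoromethyl group, so the estimate rests on indirect evidence. The 4-chlorophenyl of compound 1 gave the lowest number, and the steps away from it were large for a number 30.5 percentage points higher from compound 1 to compound 2 (beyond the scatter) and modest for a number 17 percentage points higher from compound 1 to compound 3 (beyond the scatter). Compound 4 regains the 4-chloro of compound 1, which points downward from compound 3. Its 3-(trifluoromethyl) part has only a loose parallel in the chloro for fluoro exchange, a number 13.5 percentage points lower from compound 2 to compound 3 (beyond the scatter), which also went down. Both comparisons favour a lower number, though three compounds support this only weakly.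

The expected change is a modest fall in this assay, estimated as a number 11.2 percentage points lower from compound 3 to compound 4 (beyond the scatter).

The estimate for compound 4 is 5%, with an expected range from -10% to 25%.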

Compound 4, percent growth inhibition at one concentration: -11.2%
Estimate against measurement, compound 4: 16.2 percentage points above; measured number below the stated range.
By their numbers in this assay, from the lowest: compound 4; then compound 1; then compound 3; then compound 2.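

Adding trifluoromethyl to the 4-chlorophenyl gives a number 10.4 percentage points lower from compound 1 to compound 4 (beyond the scatter), so in this assay the number can still fall from the level of the 4-chlorophenyl, and this is the first measured step that adds this group to the aryl on the amide-type nitrogen. Replacing the other aryl groups with 4-chloro-3-(trifluoromethyl)phenyl gives a number 27.4 percentage points lower from compound 3 to compound 4 (beyond the scatter) and a number 40.9 percentage points lower from compound 2 to compound 4 (beyond the scatter), which widens the spread at this position, and among these four compounds the two that carry a 4-chloro, compound 1 and compound 4, hold the two lowest numbers, with no compound against that pattern. Nothing in hand gives a reason for these falls.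

On these data alone, with the trifluoromethyl seen only alongside the 4-chloro, the share of the fall that belongs to the trifluoromethyl itself stays open, and a 3-(trifluoromethyl)phenyl without the chlorine, or a plain phenyl, would separate the two. Also open, as far as these compounds go, is whether a 3-aminophenyl or a 3-carboxyphenyl on the same nitrogen would carry this assay past the highest number so far, where compound 2 stands at 29.7%.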